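Swapping chloro for amino on a fused aromatic ring

The source may hold more compounds than are shown below. What is called first, only, known or untested is meant among the compounds shown, and "the series" means these compounds.

Measured compounds:
Compound 1, `Nc1nn(C(=O)Nc2ccc(Cc3ccccc3)cc2)c2ccccc12`: 22200 nM
Compound 2, `Nc1nn(C(=O)Nc2ccc(Cc3ccccc3)cc2)c2ccc(Cl)cc12`: 13500 nM

Both were tested in a functional assay on RXF 393 cells (Homo sapiens) for antiproliferative activity, read by sulforhodamine B assay, with a stated time of 48 h; on this read-out lower numbers stand for stronger inhibition of growth and higher numbers for weaker inhibition of growth. Within the data shown here, compound 2 gives the lowest of the two numbers, but the only measured step, a 1.6-fold lower number from compound 1 to compound 2 (0.22 log units; within the scatter), lies within the scatter, so compound 1 and compound 2 are not separated.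

Compound 3, `Nc1ccc2c(c1)c(N)nn2C(=O)Nc1ccc(Cc2ccccc2)cc1`, is not yet measured. It differs from compound 2 by amino in place of chloro on an aromatic carbon. Among the measured compounds shown here, no measured step touches this change; the one step that exists, chloro for hydrogen, was within the scatter. A step of no size beyond the scatter in this assay is therefore expected, a 1.3-fold higher number from compound 2 to compound 3 (0.12 log units; within the scatter). For compound 3 the estimate is 18000 nM, between 7000 nM and 45000 nM.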

Compound 3, concentration for 50% growth inhibition: 21400 nM
Beside the measured number, compound 3's estimate is 1.2-fold (0.08 log units) below it, within the range that was stated.
By their numbers in this assay, from the lowest: compounds 2, 3 and 1 (each within the scatter of the next).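

On this aromatic carbon, amino cannot be told apart from chloro (a 1.6-fold higher number from compound 2 to compound 3 (0.20 log units; within the scatter)) or from plain hydrogen (a 1.0-fold lower number from compound 1 to compound 3 (0.02 log units; within the scatter)). With amino added, three different groups at this one place now lie within the scatter of one another in this assay, so the earlier chloro step no longer stands alone. No evidence is available to explain this. Still open, from the compounds shown here alone, is whether a carboxylic acid or a longer chain on this carbon would give a step beyond the scatter, and whether amino would behave the same on another carbon of this ring.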